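The source may hold more compounds than are shown below. What is called first, only, known or untested is meant among the compounds shown, and "the series" means these compounds.

Working notes on the thienopyrimidine-hydrazone set.

Three compounds carry numbers in a functional assay on HCT-116 cells (Homo sapiens) for cytotoxicity, read by MTT assay, with a stated time of 3 days; a higher number here means a weaker inhibitor, a lower number a stronger inhibitor. Compound 1 `CC(C)(C)c1cc2c(N/N=C/c3ccc4c(c3)CNCC4)ncnc2s1` gives 0.107 ug/mL in this assay. Compound 2 `CN(C)Cc1ccc(/C=N/Nc2ncnc3sc(C(C)(C)C)cc23)cc1` gives 0.128 ug/mL in this assay. Compound 3 `CC(C)(C)c1cc2c(N/N=C/c3ccc(CN)cc3)ncnc2s1` gives 0.334 ug/mL in this assay, the highest of the three numbers; its nearest neighbour is compound 2, and compound 1 stands furthest from it.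

Going by the values given here, the only single-point step measured so far runs a 2.6-fold higher number from compound 2 to compound 3 (0.42 log units; beyond the scatter); the difference is modest but sits beyond the scatter.

Compound 4 `CNCc1ccc(/C=N/Nc2ncnc3sc(C(C)(C)C)cc23)cc1` has not been measured. It differs from compound 3 as follows: methyl in place of hydrogen on an amine nitrogen. This is the same site that the step from compound 2 to compound 3 concerns, and compound 4 stands between the two: a methylamino group in place of the amino of compound 3, and short of the dimethylamino of compound 2. Compound 1, with its secondary amine in a ring, gives 0.107 ug/mL, which also points toward a lower number than compound 3.

On that basis compound 4 is expected to give a lower number than compound 3 in this assay, by about a 1.8-fold lower number from compound 3 to compound 4 (0.24 log units; within the scatter), a step likely to land near or just beyond the scatter. The estimate for compound 4 in this assay is 0.19 ug/mL, with a range of 0.09 ug/mL to 0.38 ug/mL.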

Compound 4, half-maximal inhibitory concentration: 0.056 ug/mL
Compound 4: middle estimate off by 3.4-fold (0.53 log units), on the high side, outside the stated range (below it).
By their numbers in this assay, from the lowest: compounds 4, 1 and 2 (each within the scatter of the next, the first and the last beyond it); then compound 3.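

In this assay, the amine nitrogen on the saturated chain carbon does not respond in one direction to added methyl groups: the first methyl gives a 6.0-fold lower number from compound 3 to compound 4 (0.78 log units; beyond the scatter), whereas removing one methyl from the dimethylamino group gives a 2.3-fold lower number from compound 2 to compound 4 (0.36 log units; beyond the scatter). The earlier step from dimethylamino to amino, taken alone, could be read as a simple preference for more methyl on this nitrogen, but the methylamino group now gives the lowest number of the three. Both of its steps lie beyond the scatter. The compounds show the size and direction of these changes, but no measurement shown here bears on what lies behind them.

As far as these compounds go, with only hydrogen and methyl compared on this nitrogen, it remains open whether the low number is particular to methylamino or extends to an ethylamino or isopropylamino group. From the compounds shown here alone, it is also open whether a pyrrolidine or morpholine ring in place of the open-chain amine would keep the number this low.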